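The compounds below may be only part of what the source reports. "The series", "measured", "known", "first", "only" and "open" are said of these compounds alone.

Measured so far:
- Compound 1, `C=CCCCCOc1ccccc1-c1cnc(OCCC=C)n1C`: 17000 nM
- Compound 2, `C=CCCCCCOc1ncc(-c2ccccc2OCCCCC=C)n1C`: 79000 nM

In a functional assay on SK-MEL-28 cells (Homo sapiens) for inhibition, read by colorimetric assay and MTT assay, with a stated time of 72 h (on this read-out lower numbers stand for stronger inhibition and higher numbers for weaker inhibition), compound 2 stands as the highest of the two numbers recorded; its nearest neighbour is compound 1, and the pair is joined by a 4.6-fold higher number from compound 1 to compound 2 (0.67 log units; beyond the scatter). Compound 3, `C=CCCCCOc1ccccc1-c1cnc(OC)n1C`, has not yet been measured in this assay. It differs from compound 2 by hydrogen in place of hex-5-en-1-yl on a saturated chain carbon bound to an oxygen on an aromatic ring.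

Within the data shown here, only one measured step bears on this change, a 4.6-fold higher number from compound 1 to compound 2 (0.67 log units; beyond the scatter), in which the chain on the same oxygen grew longer and the number rose modestly beyond the scatter. Among the measured compounds shown here, the change to compound 3 runs the other way, cutting that chain back to a methoxy, so a move in the opposite direction is the most reasonable expectation, though the cut is made at a different place and only a single step supports it. Compound 3 is therefore expected to give a somewhat lower number, estimated as a 5.3-fold lower number from compound 2 to compound 3 (0.72 log units; beyond the scatter), landing near 15000 nM with a likely range from 5000 nM to 50000 nM.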

Compound 3, half-maximal inhibitory concentration: 85000 nM
Compound 3: the middle estimate sits 5.7-fold (0.75 log units) below what was measured; measured number above the stated range.
By their numbers in this assay, from the lowest: compound 1; then compounds 2 and 3 (each within the scatter of the next).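

Cutting the (hept-6-en-1-yl)oxy group back to methoxy leaves the read-out in this assay essentially unchanged, with a 1.1-fold higher number from compound 2 to compound 3 (0.03 log units; within the scatter), so these two very different groups cannot be told apart here. Replacing the allyl end of the corresponding chain of compound 1 with hydrogen instead gives a 5.0-fold higher number from compound 1 to compound 3 (0.70 log units; beyond the scatter), which shows that compound 1 is the strongest of the three and that the number does not follow chain size in a single direction: compound 1, with the chain of intermediate size, stands apart, whereas compound 2 and compound 3, with the longest and shortest groups, do not differ. No evidence is available to explain why the chain of compound 1 stands apart from the other two groups.

Among these compounds, with only three groups at this place, it remains open whether the lower number belongs to a narrow range of chain sizes or depends on the terminal double bond. A saturated butoxy chain, a pentenyloxy chain or an amine at this place would bear on that question, and even compound 1 remains a weak inhibitor at 17000 nM.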